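Removing one trifluoromethyl from the diaryl urea terminus

The source may hold more compounds than are shown below. What is called first, only, known or untested is meant among the compounds shown, and "the series" means these compounds.

Three compounds of the shared core have numbers in a functional assay on SNB-75 cells (Homo sapiens) for inhibition, read by sulforhodamine B assay, with a stated time of 48 h, tested at 0.01 uM; a lower number here means a stronger effect, a higher number a weaker effect of the compound at the concentration tested. Compound 1 `O=C(Nc1cccc(-n2cc(-c3ccncc3)c(-c3cc(O)cc(Cl)c3)n2)c1)Nc1ccc(Cl)c(C(F)(F)F)c1` gives 53%, compound 2 `O=C(Nc1cccc(-n2cc(-c3ccncc3)c(-c3cc(O)cc(Cl)c3)n2)c1)Nc1ccc(Cl)c(Cl)c1` gives 94%, and compound 3 `COc1cc(Cl)cc(-c2nn(-c3cccc(NC(=O)Nc4cc(C(F)(F)F)cc(C(F)(F)F)c4)c3)cc2-c2ccncc2)c1` gives 71%, which is the second highest of the three, standing nearer to compound 1 than to compound 2.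

Among the measured compounds shown here, the only measured step within this set is a number 41 percentage points higher from compound 1 to compound 2 (beyond the scatter), a large rise in the read-out, that is a clear weakening, when the group on the aromatic carbon changes. Compound 4 `COc1cc(Cl)cc(-c2nn(-c3cccc(NC(=O)Nc4cccc(C(F)(F)F)c4)c3)cc2-c2ccncc2)c1` differs from compound 3 by hydrogen in place of trifluoromethyl on an aromatic carbon. For the measured compounds named here, no measured pair shows this exact change, so the step from compound 1 to compound 2 is the nearest guide; it concerns a different entering group, yet it shows that altering a trifluoromethyl on this terminus moves the number far beyond the scatter.

A rise in the read-out is therefore expected for compound 4, with a number 12 percentage points higher from compound 3 to compound 4 (beyond the scatter) as the estimated step. Compound 4 is expected to give about 83% in this assay , within a range from 62% to 100%.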

Compound 4, a percentage reported as activity, at one concentration (the size of the read-out at that concentration, not a potency): 83%
For compound 4 middle estimate and measured number coincide at the digits printed; the measured number falls inside the stated range.
By their numbers in this assay, from the lowest: compound 1; then compound 3; then compound 4; then compound 2.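

In this assay, replacing one trifluoromethyl with hydrogen gives a number 12 percentage points higher from compound 3 to compound 4 (beyond the scatter), so this position on the urea terminus responds to simple loss of the group, even with the other trifluoromethyl group still in place. This adds to a number 41 percentage points higher from compound 1 to compound 2 (beyond the scatter), but that step has chloro as the entering group and belongs to a different substitution pattern, so the sizes of the two steps cannot be ranked as effects of one change. The measurements carry no information on why the number rises at this position.

On these data alone, what an amine or a nitrile would do in place of hydrogen at this position remains open. Also open, as far as these compounds go, is whether the same change gives a similar step on the core of compound 1.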